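A few compounds are considered here, and "the series" means these few. Any claim that something is new, unique, unknown or untested is made for them only; others in the source may bear on it.

In a functional assay on MCF7 cells (Homo sapiens) for cytotoxicity, read by MTT assay, with a stated time of 72 h (on this read-out lower numbers stand for stronger inhibition and higher numbers for weaker inhibition), compound 1 `COc1cc2ncnc(Nc3ccc(F)c(Cl)c3)c2cc1NC(=O)N/N=C/c1ccc([N+](=O)[O-])cc1` gives 36800 nM and compound 2 `COc1ccc(/C=N/NC(=O)Nc2cc3c(Nc4ccc(F)c(Cl)c4)ncnc3cc2OC)cc1` gives 8140 nM. Among the compounds with values here, compound 2 therefore holds the lower of the two numbers so far. The next structure is compound 3 `COc1cc2ncnc(Nc3ccc(F)c(Cl)c3)c2cc1NC(=O)N/N=C/c1cc(OC)c(OC)c(OC)c1`, which keeps the core of compound 2 and differs from it as follows: 3,4,5-trimethoxyphenyl in place of 4-methoxyphenyl on a carbon with a double bond to nitrogen. In words, this is 3,4,5-trimethoxyphenyl in place of 4-methoxyphenyl on a carbon with a double bond to nitrogen.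

Within the data shown here, only one measured step bears on this change: a 4.5-fold lower number from compound 1 to compound 2 (0.66 log units; beyond the scatter), a modest step with methoxy in place of nitro on an aromatic carbon. It shows what exchanging nitro for methoxy does, but not what adding further methoxy groups to an aromatic ring already carrying one does, so it gives only weak support for a direction. No step beyond the scatter is therefore expected in this assay, with at most a slight continuation of the earlier trend. The estimated step is a 1.2-fold lower number from compound 2 to compound 3 (0.07 log units; within the scatter). The estimate for compound 3 is 7000 nM, with an expected range of 2500 nM to 20000 nM.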

Compound 3, half-maximal inhibitory concentration: 30700 nM
For compound 3 the middle estimate is 4.4-fold (0.64 log units) below the measured one; measured number outside the range, above it.
By their numbers in this assay, from the lowest: compound 2; then compounds 3 and 1 (each within the scatter of the next).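

Notes on the series: in this assay the ring on the carbon with a double bond to nitrogen does not follow a simple rule of more methoxy groups, since 3,4,5-trimethoxyphenyl in place of 4-methoxyphenyl gives a 3.8-fold higher number from compound 2 to compound 3 (0.58 log units; beyond the scatter) and so reverses the direction of a 4.5-fold lower number from compound 1 to compound 2 (0.66 log units; beyond the scatter) rather than extending it. Exchanging 4-nitrophenyl for 3,4,5-trimethoxyphenyl gives a 1.2-fold lower number from compound 1 to compound 3 (0.08 log units; within the scatter) and this lies within the scatter, which leaves compound 2 as the only one of the three that stands apart, with its steps to both others beyond the scatter. No available evidence accounts for this reversal at the position.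

Within the data shown here, with only three rings compared, the shape of the response remains open: a plain phenyl ring, or a phenyl ring carrying two methoxy groups, could show whether the change tracks the number of methoxy groups or something specific to the trimethoxy pattern. Among these compounds, also open is how an amine, a hydroxyl or a carboxylic acid on this ring would compare with the single methoxy group of compound 2 in this assay when the shared core is kept unchanged.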